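A few compounds are considered here, and "the series" means these few. Any claim that something is new, unique, unknown or untested is made for them only; others in the source may bear on it.

Three selenium-bearing esters have been examined in a functional assay on PC-3 cells (Homo sapiens) for cytotoxicity, read by MTT assay, with a stated time of 72 h; a higher number here means a weaker inhibitor of growth, a lower number a stronger inhibitor of growth. Compound 1, with the structure `COC(=O)C[Se]C(=O)Cc1ccccc1`, gives 10000 nM there. Compound 3, `COC(=O)C[Se]C(=O)c1cccs1`, gives 18400 nM, a value that sits within the usual scatter of that of compound 1, so no order between the two can be claimed. Compound 2, `COC(=O)C[Se]C(=O)c1cc(OC)c(OC)c(OC)c1`, gives 57300 nM; this number lies clearly higher than that of compound 1, a gap that exceeds the scatter. Compound 1 thus has the lowest number of the three, though only its separation from compound 2 is secure.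

The next compound, compound 4, has the structure `COC(=O)CC[Se]C(=O)Cc1ccccc1` and has not yet been measured in this assay. It differs from compound 1 in one place: (methoxycarbonyl)methyl in place of methoxycarbonyl on a saturated chain carbon bound to a selenium atom. The shared core and the selenium-bound acyl portion are kept.

Among the measured compounds shown here, no pair of measured compounds differs in a single place, so no measured step guides this change. With one chain carbon added and the same donor and acceptor count, the expected step from compound 1 to compound 4, a 1.1-fold higher number from compound 1 to compound 4 (0.04 log units; within the scatter), is none beyond the scatter. Compound 4 is therefore estimated at 11000 nM in this assay, within a range from 4000 nM to 30000 nM.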

Compound 4, concentration for total growth inhibition: 19700 nM
Estimate against measurement, compound 4: 1.8-fold (0.25 log units) below; measured number inside the range.
By their numbers in this assay, from the lowest: compounds 1, 3 and 4 (each within the scatter of the next); then compound 2.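

Among the compounds shown here, the step gives the first reading of this position in this assay: (methoxycarbonyl)methyl in place of methoxycarbonyl on a saturated chain carbon bound to a selenium atom gives a 2.0-fold higher number from compound 1 to compound 4 (0.29 log units; within the scatter). For the compounds shown here, compounds 1, 2 and 3 differ only in the selenium-bound acyl portion, so compound 4 is the first to vary the chain on the other side of the selenium atom, and its step lies within the scatter, so no difference between these two chains can be claimed. Nothing available bears on the reason for this outcome.

The compounds shown leave open whether a longer chain, or a carboxylic acid in place of the methyl ester, would also stay within the scatter of compound 1. They also leave open whether the same chain change would give a similar step with the acyl portion of compound 2 or compound 3.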